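Swapping an Ester Tail on a Thiophene-Bearing Core

The compounds below may be only part of what the source reports. "The series", "measured", "known", "first", "only" and "open" are said of these compounds alone.

Measured compounds:
compound 1, `CC1=C(C(=O)OC2CCC2)C(c2ccoc2)NC(=O)N1`, 307 nM
compound 2, `CC1=C(C(=O)OCC2CC2)C(c2ccoc2)NC(=O)N1`, 426 nM
compound 3, `CC1=C(C(=O)OC2CCC2)C(c2cccs2)NC(=O)N1`, 1090 nM

All three were tested in an assay on membranes from HEK293 cells for displacement of a labelled ligand from adenosine receptor A2b (Homo sapiens), read by scintillation counting, with a stated time of 30 min; on this read-out lower numbers stand for stronger inhibition and higher numbers for weaker inhibition. Compound 1 and compound 2 share one core and differ only in the ester tail: cyclopropylmethyl in place of cyclobutyl on an oxygen next to a carbonyl group. That change gave a 1.4-fold higher number from compound 1 to compound 2 (0.14 log units; within the scatter). Compound 3 carries a different aromatic ring on the core than compound 1: thiophen-2-yl in place of furan-3-yl on a saturated ring carbon. That change gave a 3.6-fold higher number from compound 1 to compound 3 (0.55 log units; beyond the scatter), and compound 3 has the highest number of the three.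

Compound 4, `CC1=C(C(=O)OCC2CC2)C(c2cccs2)NC(=O)N1`, has not yet been measured. It stands to compound 3 as compound 2 stands to compound 1: cyclopropylmethyl in place of cyclobutyl on an oxygen next to a carbonyl group. The place is the same in both pairs, so this is the same change made twice, once on each core. Since the earlier step was a 1.4-fold higher number from compound 1 to compound 2 (0.14 log units; within the scatter), the step from compound 3 to compound 4 in this assay is expected to be of about that size, a 1.4-fold higher number from compound 3 to compound 4 (0.14 log units; within the scatter), resting on that single pair. Compound 4 is therefore estimated at 1500 nM, expected to lie between 700 nM and 3300 nM.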

Compound 4, inhibition constant: 1570 nM
Beside the measured number, compound 4's estimate is 1.0-fold (0.02 log units) below it, within the range that was stated.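

In this assay, cyclopropylmethyl in place of cyclobutyl gives a 1.4-fold higher number from compound 3 to compound 4 (0.16 log units; within the scatter) on the core of compound 3, and the step carries over from the core of compound 1 with no visible change in size: the same change on two cores in this assay, a 1.4-fold higher number (0.14 log units; within the scatter) from compound 1 to compound 2 and a 1.4-fold higher number (0.16 log units; within the scatter) from compound 3 to compound 4, 1.0-fold (0.02 log units) apart, within the scatter of two such steps. The second change also carries over, as thiophen-2-yl in place of furan-3-yl gives a 3.7-fold higher number from compound 2 to compound 4 (0.57 log units; beyond the scatter) with the cyclopropylmethyl tail, matching the step seen with the cyclobutyl tail: the same change on two cores in this assay, a 3.6-fold higher number (0.55 log units; beyond the scatter) from compound 1 to compound 3 and a 3.7-fold higher number (0.57 log units; beyond the scatter) from compound 2 to compound 4, 1.0-fold (0.02 log units) apart, within the scatter of two such steps. Within these four compounds the two changes therefore appear to act independently, but this rests on a single set of two cores and two tails, and since the tail step lies within the scatter, it shows only that the step stays small on both cores, not that the two tails truly differ.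

As far as these compounds go, it remains open whether the same independence would hold for a tail of another kind, such as a longer chain or one ending in an amine. The same question applies to a carboxylic acid in place of the ester.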